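Swapping a Fluoro for Methyl on the Benzyl Arm

This account rests on a few compounds, and the source may have more. Where it says the series, first, only, none or still open, it means among the compounds named here.

Three compounds sharing one core have been measured in an assay on isolated protein for inhibition of histone deacetylase 8 (Homo sapiens), read by mobility shift assay; a lower number here means a stronger inhibitor, a higher number a weaker inhibitor:
- Compound 1, `O=C(NO)c1ccc(CN(Cc2ccccc2)S(=O)(=O)c2c(F)c(F)c(F)c(F)c2F)cc1`, gives 150 nM.
- Compound 2, `O=C(NO)c1ccc(CN(Cc2ccc(F)cc2)S(=O)(=O)c2c(F)c(F)c(F)c(F)c2F)cc1`, gives 367 nM.
- Compound 3, `O=C(NO)c1ccc(CN(Cc2ccc(C(F)(F)F)cc2)S(=O)(=O)c2c(F)c(F)c(F)c(F)c2F)cc1`, reaches only the limit of the method, > 1000 nM.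

Compound 2 holds the highest of the two plain numbers, and its nearest neighbour is compound 1 a 2.4-fold higher number from compound 1 to compound 2 (0.39 log units; beyond the scatter). The third value is a limit of the method, not a number (the limit of > 1000 nM in this assay, at which 1 of the 3 values shown sits).

Compound 4, `Cc1ccc(CN(Cc2ccc(C(=O)NO)cc2)S(=O)(=O)c2c(F)c(F)c(F)c(F)c2F)cc1`, is not yet measured. Against compound 2 the change is methyl in place of fluoro on an aromatic carbon.

Within the data shown here, two measured steps bear on this change, both altering the same position of the same ring. The step of a 2.4-fold higher number from compound 1 to compound 2 (0.39 log units; beyond the scatter) and the step of an at least 2.7-fold higher number from compound 2 to compound 3 (0.43 log units; beyond the scatter) both run towards weaker inhibition as the group there grows. A methyl is a single heavy atom, like fluoro, and unlike trifluoromethyl. The step of a 1.4-fold higher number from compound 2 to compound 4 (0.13 log units; within the scatter) is therefore expected to be small, most likely a slight loss or no change beyond the scatter. For compound 4 the estimate is 500 nM, within the range 200 nM to 1400 nM.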

Compound 4, half-maximal inhibitory concentration: 101 nM
The estimate for compound 4 lay 5.0-fold (0.69 log units) above the measured number; measured number outside the range, below it.
By their numbers in this assay, from the lowest: compounds 4 and 1 (each within the scatter of the next); then compound 2. At a limit, above all of these: compound 3.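

Fluoro and methyl each bring one heavy atom, yet exchanging one for the other at this position in this assay is not a neutral swap: the step is a 3.6-fold lower number from compound 2 to compound 4 (0.56 log units; beyond the scatter). Methyl in place of hydrogen gives a 1.5-fold lower number from compound 1 to compound 4 (0.17 log units; within the scatter), so a group on this carbon need not bring a loss, and compound 4 goes against the reading from the earlier compounds, where the number rose from hydrogen to fluoro to trifluoromethyl. Compound 3 gives only a limit and not a number, so an at least 9.9-fold lower number from compound 3 to compound 4 (0.99 log units; beyond the scatter) sets a minimum size for that step: the limit of > 1000 nM in this assay, at which 1 of the 4 values shown sits.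

The compounds shown carry only hydrogen, fluoro, methyl and trifluoromethyl on this carbon, so it remains open what an ethyl, a methoxy or an amine would do there, and whether any larger group could match the methyl. Among these compounds, nothing here tells why methyl and fluoro part ways, or whether the same swap would give a similar step on a core other than the one shared by these compounds.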